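The compounds below may be only part of what the source reports. "The series", "measured", "known", "first", "only" and "open" are said of these compounds alone.

Measured compounds, in an ADME assay on HEK-293T cells (Homo sapiens) for cytotoxicity; on this read-out higher numbers stand for lower toxicity in this test and lower numbers for higher toxicity in this test:
- compound 1 `COC(c1cc(C)cc(C)c1)c1c[nH]c2ccc(Cl)cc12`: 67700 nM
- compound 2 `COC(c1ccccc1)c1c[nH]c2ccc(Cl)cc12`: 67000 nM
- compound 3 `CCOC(=O)c1[nH]c2ccc(Cl)cc2c1C(OC)c1ccccc1`: 25300 nM

Compound 3 carries the lowest number of the three. Going by the values given here, the single change from compound 2 gave a 2.6-fold lower number from compound 2 to compound 3 (0.42 log units; beyond the scatter), and compound 1 sits a little further away again, so compound 3 is the most cytotoxic of the set by a modest margin.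

Compound 4 `CCOC(=O)c1[nH]c2ccc(Cl)cc2c1C(OC)c1cc(C)cc(C)c1` is the next step. It differs from compound 3 by 3,5-dimethylphenyl in place of phenyl on a saturated chain carbon bound to an aromatic carbon and an oxygen on a saturated carbon.

Among the compounds with values here, no computed step exists for this exchange, but the same swap, 3,5-dimethylphenyl in place of phenyl on the saturated chain carbon bound to an aromatic carbon and an oxygen on a saturated carbon, separates compound 2 from compound 1. In this assay compound 2 gives 67000 nM and compound 1 gives 67700 nM; those two numbers lie within the scatter of each other. On that basis the step to compound 4 is expected to be a 1.0-fold lower number from compound 3 to compound 4 (0.01 log units; within the scatter), no real movement either way.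

Compound 4 is therefore estimated at 25000 nM, with a range from 12000 nM to 50000 nM.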

Compound 4, half-maximal cytotoxic concentration: 36500 nM
Compound 4: the middle estimate sits 1.5-fold (0.16 log units) below what was measured, within the range that was stated.
By their numbers in this assay, from the lowest: compounds 3, 4, 2 and 1 (each within the scatter of the next, the first and the last beyond it).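

In this assay, the exchange of phenyl for 3,5-dimethylphenyl on the saturated chain carbon can now be read with ethoxycarbonyl present, as a 1.4-fold higher number from compound 3 to compound 4 (0.16 log units; within the scatter), so it stays within the scatter here, as the printed values of compound 2 and compound 1 also do without that group. Ethoxycarbonyl in place of hydrogen on an aromatic carbon also gets a second reading, a 1.9-fold lower number from compound 1 to compound 4 (0.27 log units; within the scatter), which does not clear the scatter on this core, unlike the step on the core of compound 2. The two readings of that change still agree: the same change on two cores in this assay, a 2.6-fold lower number (0.42 log units; beyond the scatter) from compound 2 to compound 3 and a 1.9-fold lower number (0.27 log units; within the scatter) from compound 1 to compound 4, 1.4-fold (0.15 log units) apart, within the scatter of two such steps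

Open, from the compounds shown here alone, is whether a carboxylic acid or an amine in place of ethoxycarbonyl on that aromatic carbon would shift the number beyond the scatter. Also open, going by these compounds, is what a longer alkyl chain in place of 3,5-dimethylphenyl on the saturated chain carbon would give.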